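A few compounds are considered here, and "the series" means these few. Any claim that something is new, unique, unknown or untested is made for them only; others in the source may bear on it.

Measured so far:
compound 1 `Cc1cn([C@@H]2O[C@H](CO[Si](C)(C)C(C)(C)C)[C@@]3(OS(=O)(=O)C=C3NCCC(N)=O)[C@H]2O[Si](C)(C)C(C)(C)C)c(=O)n(C)c1=O`: 20000 nM
compound 2 `C=C(C)C(=O)NC(=O)NC1=CS(=O)(=O)O[C@@]12[C@@H](CO[Si](C)(C)C(C)(C)C)O[C@@H](n1cc(C)c(=O)n(C)c1=O)[C@@H]2O[Si](C)(C)C(C)(C)C`: 1190 nM

In a functional assay on MT4 cells (Homo sapiens) (a higher number here means that more compound is tolerated, a lower number that less compound is tolerated), compound 1 gives 20000 nM, while compound 2 gives 1190 nM. Among the measured compounds shown here, compound 2 therefore stands at the lower of the two numbers, with compound 1 as its only neighbour; the single measured step, a 17-fold lower number from compound 1 to compound 2 (1.23 log units; beyond the scatter), arose from ((1-methylethenyl)carbonyl)carbamoyl in place of 2-carbamoylethyl on an amine nitrogen.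

Compound 3 `COC(=O)NC1=CS(=O)(=O)O[C@@]12[C@@H](CO[Si](C)(C)C(C)(C)C)O[C@@H](n1cc(C)c(=O)n(C)c1=O)[C@@H]2O[Si](C)(C)C(C)(C)C` has not yet been measured in this assay. It differs from compound 2 in one place: methoxy in place of ((1-methylethenyl)carbonyl)amino on a carbonyl carbon. For the measured compounds named here, no measured step covers this exact exchange. Going by the values given here, the only step that bears on it is a 17-fold lower number from compound 1 to compound 2 (1.23 log units; beyond the scatter), which shows that the group on the amine nitrogen sets the number strongly and that the ((1-methylethenyl)carbonyl)carbamoyl group goes with the lowest number seen. Taking away the ((1-methylethenyl)carbonyl)amino part and leaving methoxycarbonyl is accordingly expected to move the number back upward, beyond the scatter, though the size is uncertain. Compound 3 is estimated at 8000 nM, within 2000 nM to 30000 nM. The expected step of a 6.7-fold higher number from compound 2 to compound 3 (0.83 log units; beyond the scatter) is thus an estimate of a rise beyond the scatter.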

Compound 3, half-maximal cytotoxic concentration: 29900 nM
Estimate against measurement, compound 3: 3.7-fold (0.57 log units) below; low and high end bracket the measured number.
By their numbers in this assay, from the lowest: compound 2; then compounds 1 and 3 (each within the scatter of the next).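

In this assay, replacing the ((1-methylethenyl)carbonyl)amino part with methoxy gives a 25-fold higher number from compound 2 to compound 3 (1.40 log units; beyond the scatter), so the low number of compound 2 depends on that part and is not set by the shared core alone. The other comparison gives a 1.5-fold higher number from compound 1 to compound 3 (0.17 log units; within the scatter), so the 2-carbamoylethyl and methoxycarbonyl groups on the amine nitrogen cannot be told apart here, and among these three compounds only compound 2 stands apart. No information is available that would explain why this one group goes with so much less compound being tolerated.

The compounds shown do not reveal whether the low number needs the whole ((1-methylethenyl)carbonyl)carbamoyl group or only its carbon-carbon double bond, a question that a saturated 2-methylpropanoyl group in the place of the 1-methylethenyl-bearing acyl group would address. They also leave open where a free amine or a longer alkyl chain on the same nitrogen would fall relative to these three numbers.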